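A few compounds are considered here, and "the series" means these few. Any claim that something is new, unique, unknown or untested is made for them only; others in the source may bear on it.

Compound 1 `Cc1csc(N)c1C(=O)c1ccc(Cl)cc1`: 1% in an assay on CHO cells for displacement of a labelled ligand from adenosine receptor A1 (Homo sapiens), read by scintillation counting, tested at 10 uM; a lower number here means less inhibition, a higher number more inhibition at the concentration tested (going by the name of the read-out)
Compound 2 `CC(C)(C)c1csc(N)c1C(=O)c1ccc(Cl)cc1`: 1% in this assay
Compound 3 `CC(C)(C)Cc1csc(N)c1C(=O)c1ccc(Cl)cc1`: 1% in this assay

Compound 1 stands level with compounds 2 and 3 in this assay; all three sit at the bottom of the read-out. Compound 4 `Cc1c(-c2ccccc2)sc(N)c1C(=O)c1ccc(Cl)cc1` differs from compound 1 by phenyl in place of hydrogen on an aromatic carbon. The measured steps all concern the methyl group of the shared core: no change at the digits printed from compound 1 to compound 2 (within the scatter), no change at the digits printed from compound 1 to compound 3 (within the scatter) and no change at the digits printed from compound 2 to compound 3 (within the scatter). None of them places a group on an aromatic carbon of the five-membered ring itself, so none bears directly on the change to compound 4. With every measured step flat and compound 1 already at the floor, the expectation for compound 4 is again no step beyond the scatter, a number 2 percentage points higher from compound 1 to compound 4 (within the scatter). Compound 4 is therefore estimated at 3%, within -8% to 20%.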

Compound 4, a percentage reported as inhibition, at one concentration (the size of the read-out at that concentration, not a potency): 1%
The estimate for compound 4 lay 2 percentage points above the measured number; measured number inside the range.
By their numbers in this assay, from the lowest: compounds 1, 2, 3 and 4 (each within the scatter of the next).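

Phenyl in place of hydrogen on an aromatic carbon, next to the ring sulfur, gives no change at the digits printed from compound 1 to compound 4 (within the scatter) in this assay. For the compounds shown here, this is the first measured change on the five-membered ring itself, and even this six-carbon ring at that place leaves compound 4 level with compounds 1, 2 and 3. No measurement shown accounts for this flat result.

On these data alone, whether an amine, a carboxylic acid or a longer chain at this position would lift the number stays open. So does whether any group here could raise the read-out of this assay above the level of these compounds.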